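Switching the sulfonamide aryl group: toluene to anisole

This account rests on a few compounds, and the source may have more. Where it says the series, first, only, none or still open, it means among the compounds named here.

This short series shares a sulfonamide linked to a benzoxazole-type core, and three compounds have been tested in an ADME assay on HEK293 cells (Homo sapiens) for cytotoxicity, read by resazurin assay, with a stated time of 48 h; on this read-out higher numbers stand for lower toxicity in this test and lower numbers for higher toxicity in this test. Compound 1 `Cc1ccc(S(=O)(=O)Nc2ccc3oc(-c4ccccc4)nc3c2)cc1` gives 75000 nM. Compound 2 `O=S(=O)(Nc1ccc2oc(-c3ccccc3)nc2c1)c1ccc(Cl)c(C(F)(F)F)c1`, with a different aryl group on the sulfonyl sulfur, gives 66000 nM, a number that sits within the usual scatter of the value for compound 1, so the two cannot be told apart. Compound 3 `O=S(=O)(Nc1ccc(-c2nc3ccccc3o2)cc1)c1cccs1` reaches only a limit of the assay, > 100000 nM, and so gives no number. That limit, (the limit of > 100000 nM in this assay, at which 1 of the 3 values shown sits), shows that one member of the set is too weakly cytotoxic to be measured in the range covered.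

Compound 4 `COc1ccccc1S(=O)(=O)Nc1ccc2oc(-c3ccccc3)nc2c1` has not yet been measured. It differs from compound 1 in one place: 2-methoxyphenyl in place of 4-methylphenyl on a sulfonyl sulfur. Both aryl groups are small six-membered rings with no charge, and the two measured numbers in this series lie close together, so the expected step from compound 1 to compound 4 is a 1.1-fold higher number from compound 1 to compound 4 (0.03 log units; within the scatter), that is, no change beyond the scatter in either direction. On that basis compound 4 is estimated to give 80000 nM, with a plausible range from 40000 nM to 160000 nM.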

Compound 4, half-maximal cytotoxic concentration: 41000 nM
Beside the measured number, compound 4's estimate is 2.0-fold (0.29 log units) above it; the measured number falls inside the stated range.
By their numbers in this assay, from the lowest: compounds 4, 2 and 1 (each within the scatter of the next). At a limit, above all of these: compound 3.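

In this assay, placing 2-methoxyphenyl in place of 4-methylphenyl on the sulfonyl sulfur gives a 1.8-fold lower number from compound 1 to compound 4 (0.26 log units; within the scatter) and so cannot be told apart from no change. This is the only step shown at this position between two compounds that differ in one place, and it adds an oxygen and a hydrogen-bond acceptor to the aryl group while the read-out stays within the usual scatter of repeated measurements. Nothing measured in this series accounts for the size of this step.

The compounds shown leave open whether an aryl group carrying an amine or a carboxylic acid, or an open alkyl chain in place of the aryl ring on the sulfonyl sulfur, would give a step beyond the scatter. With a single step to read, they also cannot show whether the same exchange would behave the same way on a different core.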